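Replacing an Amino Group with Methoxy on the Chalcone Ring

The source may report more compounds than this note shows. Statements on the series, on what has been measured and on what is new or still open speak of the compounds shown alone.

Compound 1 `COc1cc(-c2cc(/C=C/C(=O)c3ccc(N)cc3)[nH]n2)cc(OC)c1OC` is measured in a functional assay on RXF 393 cells (Homo sapiens) for inhibition, read by sulforhodamine B assay, with a stated time of 48 h (on this read-out lower numbers stand for higher toxicity in this test and higher numbers for lower toxicity in this test), where compound 1 gives 7790 nM. Among the compounds with values here, its only measured companion is compound 2 `COc1cc(-c2cc(/C=C/C(=O)c3ccc(Cl)c(Cl)c3)[nH]n2)cc(OC)c1OC`, which in this assay gives 54600 nM; compound 1 thus holds the lowest of the two numbers, so it is the more toxic of the pair here. Within the data shown here, the one step on record, a 7.0-fold higher number from compound 1 to compound 2 (0.85 log units; beyond the scatter), came from putting 3,4-dichlorophenyl in place of 4-aminophenyl on a carbonyl carbon.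

Compound 3 `COc1ccc(C(=O)/C=C/c2cc(-c3cc(OC)c(OC)c(OC)c3)n[nH]2)cc1` differs from compound 1 by methoxy in place of amino on an aromatic carbon, that is, 4-aminophenyl becoming 4-methoxyphenyl. That step has not been measured. Among the measured compounds shown here, the one measured step also removed the amino group and raised the number, so for compound 3 the expected step is a 2.1-fold higher number from compound 1 to compound 3 (0.31 log units; beyond the scatter), a rise beyond the scatter that is smaller than the measured one, as it swaps a single group rather than the pattern on the ring. Compound 3 is therefore estimated at 16000 nM, within 5000 nM to 45000 nM.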

Compound 3, concentration lethal to 50% of the cells: 5170 nM
Compound 3: the middle estimate sits 3.1-fold (0.49 log units) above what was measured; the range from low to high includes it.
By their numbers in this assay, from the lowest: compounds 3 and 1 (each within the scatter of the next); then compound 2.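

In this assay, swapping the amino group for methoxy gives a 1.5-fold lower number from compound 1 to compound 3 (0.18 log units; within the scatter), so compound 1 and compound 3 cannot be told apart, even though the amino group's hydrogen-bond donor is gone. Losing the amino group alone therefore does not carry the rise seen earlier at compound 2. The ring pattern matters instead, as the move back gives an 11-fold lower number from compound 2 to compound 3 (1.02 log units; beyond the scatter) and places 4-methoxyphenyl with 4-aminophenyl, well away from 3,4-dichlorophenyl in this test.

The compounds shown leave open whether a 4-chlorophenyl or a 4-hydroxyphenyl group would stay with compound 1 and compound 3 or move toward compound 2. Nothing on hand explains why these numbers fall as they do.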